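This account rests on a few compounds, and the source may have more. Where it says the series, first, only, none or still open, it means among the compounds named here.

The measured compounds are compound 1, `C/C(=N\NC(N)=S)c1ccc2[nH]c(-c3ccc(C(F)(F)F)cc3)nc2c1`, compound 2, `C/C(=N\NC(N)=S)c1ccc2c(c1)nc(-c1ccccc1)n2C1CCCCC1`, and compound 3, `C/C(=N\NC(N)=S)c1ccc2c(c1)nc(-c1ccc(C(F)(F)F)cc1)n2C1CCCCC1`. In an ADME assay on MDBK cells (Bos taurus) for cytotoxicity, read by MTT assay, with a stated time of 96 h (a lower number here means that less compound is tolerated, a higher number that more compound is tolerated), compound 1 gives 5000 nM. In this assay compound 2 gives 24000 nM. For compound 3, this assay reports only a limit, > 100000 nM, so compound 3 stands at the top of the numbers shown and no exact value is known for it (the limit of > 100000 nM in this assay, at which 1 of the 3 values shown sits). Two steps lead to compound 3: an at least 20-fold higher number from compound 1 to compound 3 (1.30 log units; beyond the scatter), and an at least 4.1-fold higher number from compound 2 to compound 3 (0.61 log units; beyond the scatter).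

Compound 4, `C/C(=N\NC(N)=S)c1ccc2c(c1)nc(-c1ccoc1)n2C1CCCCC1`, has not yet been measured. It differs from compound 3 in one place: furan-3-yl in place of 4-(trifluoromethyl)phenyl on an aromatic carbon. The step that bears on this change is an at least 4.1-fold higher number from compound 2 to compound 3 (0.61 log units; beyond the scatter), since the trifluoromethyl that leaves together with the 4-(trifluoromethyl)phenyl group is the one whose arrival raised the number in that step. The other step, an at least 20-fold higher number from compound 1 to compound 3 (1.30 log units; beyond the scatter), does not bear on it, as cyclohexyl stays in place. The expected step is therefore an at least 3.3-fold lower number from compound 3 to compound 4 (0.52 log units; beyond the scatter), downward and of modest size, back toward the range of compound 2, though the limit on compound 3 leaves its true starting point open. The estimate for compound 4 in this assay is 30000 nM, within 10000 nM to 100000 nM.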

Compound 4, half-maximal cytotoxic concentration: > 100000 nM
Compound 4 ended at the assay's limit; the forecaster's own chance of this, stated with the estimate: 35%; middle value at least 3.3-fold (0.52 log units) away from the limit.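

In this assay compound 4 gives > 100000 nM, which is a limit of the assay and not a number. At this aromatic carbon between two ring nitrogen atoms, a trifluoromethyl group is therefore not required to move the number clear of compound 2: the change from phenyl to furan-3-yl gives an at least 4.1-fold higher number from compound 2 to compound 4 (0.61 log units; beyond the scatter). The step between compound 3 and compound 4 cannot be read, so in this assay a 4-(trifluoromethyl)phenyl group of 10 heavy atoms and a furan-3-yl group of 5 heavy atoms cannot be told apart at this position, and the top of the scale now holds both compounds: the limit of > 100000 nM in this assay, at which 2 of the 4 values shown sit.

From the compounds shown here alone, how far compound 3 and compound 4 truly lie from each other stays unknown, as does whether a group of another kind on this carbon, such as an amine, a carboxylic acid or a longer alkyl chain, would bring the number back down. Also open, going by these compounds, is whether furan-3-yl would hold the number at the limit with hydrogen in place of cyclohexyl on the aromatic nitrogen, the arrangement found in compound 1.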